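Replacing ethynyl with (4-methylphenyl)carbonyl: an expected outcome

A few compounds are considered here, and "the series" means these few. Any claim that something is new, unique, unknown or untested is made for them only; others in the source may bear on it.

Compound 1 `Cc1nnc(SCC(=O)c2ccc(Cl)cc2)n1N1C(=O)c2ccccc2C1=O`: in a functional assay on MKN-45 cells (Homo sapiens) for cytotoxicity, read by MTT assay, with a stated time of 48 h (a lower number here means a stronger inhibitor, a higher number a weaker inhibitor), compound 1 gives > 200000 nM, a limit of the assay.
Compound 2 `C#CCSc1nnc(C)n1N1C(=O)c2ccccc2C1=O`: in this assay compound 2 gives > 200000 nM, a limit of the assay.
Compound 3 `C#CCSc1nnc(CC)n1N1C(=O)c2ccccc2C1=O`: in this assay compound 3 gives > 200000 nM, a limit of the assay.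

All three measured compounds sit at the limit of > 200000 nM in this assay, at which 3 of the 3 values shown sit, so compound 3 stands at that limit with no number of its own. The measured steps a step that the two limits leave unreadable from compound 1 to compound 2 and a step that the two limits leave unreadable from compound 2 to compound 3 are therefore unreadable in size and direction. Compound 4 `CCc1nnc(SCC(=O)c2ccc(C)cc2)n1N1C(=O)c2ccccc2C1=O` differs from compound 3 by (4-methylphenyl)carbonyl in place of ethynyl on a saturated chain carbon bound to a sulfur. The nearest guide is compound 1, which carries a (4-chlorophenyl)carbonyl group on the same chain carbon and also reached only a limit. With no readable step to build on, the expected step is a step that the limit leaves unreadable from compound 3 to compound 4, that is, none beyond the scatter. Compound 4 is estimated at 250000 nM, within 100000 nM to 700000 nM, and will most likely be reported only as a limit again.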

Compound 4, half-maximal inhibitory concentration: > 200000 nM
Compound 4 gave a limit, no number; the forecaster's own chance of this, stated with the estimate: 85%; the middle value lies beyond the limit too.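

Compound 3 and compound 4 both stop at a limit rather than a number, so the change between them cannot be read in size or direction: the limit of > 200000 nM in this assay, at which 4 of the 4 values shown sit.

Which change to the shared core, if any, would give a real number instead of a limit stays open.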